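Replacing a Thioether with a Pyridylmethyl Ether on the Core

The source may report more compounds than this note shows. Statements on the series, on what has been measured and on what is new or still open speak of the compounds shown alone.

Going by the values given here, compound 3 `CCCc1cc(SC)cc(=O)n1Cc1ccc(-c2ccccc2-c2nn[nH]n2)cc1` gives 0.28 mg/kg in a functional assay on the whole organism with Rattus norvegicus as the target (a higher number here means that more compound is needed for the effect, a lower number that less compound is needed), the highest of the three numbers measured so far. Compound 1 `CCCc1cc(O)cc(=O)n1Cc1ccc(-c2ccccc2-c2nn[nH]n2)cc1` gives 0.048 mg/kg in this assay, and compound 2 `CCCc1cc(S)cc(=O)n1Cc1ccc(-c2ccccc2-c2nn[nH]n2)cc1` gives 0.017 mg/kg. The steps between these three are a 2.8-fold lower number from compound 1 to compound 2 (0.45 log units; beyond the scatter), a 5.8-fold higher number from compound 1 to compound 3 (0.77 log units; beyond the scatter) and a 16-fold higher number from compound 2 to compound 3 (1.22 log units; beyond the scatter). Compound 4 `CCCc1cc(OCc2cccnc2)cc(=O)n1Cc1ccc(-c2ccccc2-c2nn[nH]n2)cc1` differs from compound 3 in one place: (pyridin-3-yl)methoxy in place of methylsulfanyl on an aromatic carbon. Among the compounds with values here, the step that bears most on this change is the one from compound 2 to compound 3, where a methyl on the sulfur raised the number by a large amount; the new group also puts a carbon chain on the heteroatom, but on an oxygen rather than a sulfur and with a far larger group, and no measured pair shows what that does. The expected outcome is therefore uncertain, and the step expected from this change, a 1.1-fold lower number from compound 3 to compound 4 (0.05 log units; within the scatter), is within the scatter. Compound 4 is estimated at 0.25 mg/kg, with a range from 0.04 mg/kg to 1.5 mg/kg.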

Compound 4, dose for 50% inhibition: 0.72 mg/kg
The estimate for compound 4 lay 2.9-fold (0.46 log units) below the measured number; low and high end bracket the measured number.
By their numbers in this assay, from the lowest: compound 2; then compound 1; then compound 3; then compound 4.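

Going by these compounds alone, putting (pyridin-3-yl)methoxy in place of methylsulfanyl, opposite the ring nitrogen, gives a 2.6-fold higher number from compound 3 to compound 4 (0.41 log units; beyond the scatter) in this assay, so the only group here with its own ring gives the highest number of the four. The gap to the two small groups is wider, with a 42-fold higher number from compound 2 to compound 4 (1.63 log units; beyond the scatter) when it replaces sulfanyl and a 15-fold higher number from compound 1 to compound 4 (1.18 log units; beyond the scatter) when (pyridin-3-yl)methyl goes onto the oxygen of the hydroxy group, which matches the earlier rise when methyl went onto the sulfur, and neither of these two compounds with a group on the heteroatom goes against it. No measurement here explains why these numbers rise.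

A plain methoxy or benzyloxy group at this position would show whether the oxygen, the added size or the ring nitrogen matters most. Going by these compounds, an amine here is also open, and so is moving the nitrogen to another place in the pyridine ring.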